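Same Sulfonyl Swap Tried on a Second Core

A few compounds are considered here, and "the series" means these few. Any claim that something is new, unique, unknown or untested is made for them only; others in the source may bear on it.

Compound 1 `O=C(Oc1cccc2cccnc12)c1cc2c(cc1Cl)SC(N(c1ccc(F)cc1)S(=O)(=O)c1ccc(Br)s1)=NS2(=O)=O` and compound 3 `O=C(Oc1cccc2cccnc12)c1cc2c(cc1Cl)SC(N(c1ccc(F)cc1)S(=O)(=O)c1ccc(Cl)cc1)=NS2(=O)=O` share one core and differ only in 4-chlorophenyl in place of 5-bromothiophen-2-yl on a sulfonyl sulfur. In a functional assay on DAN-G cells (Homo sapiens) for cytotoxicity, with a stated time of 96 h (on this read-out lower numbers stand for stronger inhibition of growth and higher numbers for weaker inhibition of growth), compound 1 gives 8200 nM, while compound 3 gives 9300 nM, so the swap produced a 1.1-fold higher number from compound 1 to compound 3 (0.05 log units; within the scatter).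

Compound 2 `COC(=O)c1cc2c(cc1Cl)SC(N(N(C)C)S(=O)(=O)c1ccc(Br)s1)=NS2(=O)=O` is built on a different core; how its core differs from that of compound 1 is not broken down here. In this assay compound 2 gives 23700 nM, the highest of the three numbers, beyond the scatter from compound 3 and from compound 1.

Compound 4 `COC(=O)c1cc2c(cc1Cl)SC(N(N(C)C)S(=O)(=O)c1ccc(Cl)cc1)=NS2(=O)=O` stands to compound 2 as compound 3 stands to compound 1: the difference is 4-chlorophenyl in place of 5-bromothiophen-2-yl on a sulfonyl sulfur, at the same place, so it is the same change made on the second core. Going by the values given here, only one earlier instance of this change is available, and it left the number essentially unmoved. The estimated step is a 1.1-fold higher number from compound 2 to compound 4 (0.04 log units; within the scatter), because the first instance gave a 1.1-fold higher number from compound 1 to compound 3 (0.05 log units; within the scatter). Compound 4 is therefore expected to give 26000 nM in this assay, likely between 12000 nM and 55000 nM.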

Compound 4, concentration for 50% growth inhibition: 18700 nM
Compound 4: middle estimate off by 1.4-fold (0.14 log units), on the high side, and the stated range covers the measured number.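

On the second core, in this assay, putting 4-chlorophenyl in place of 5-bromothiophen-2-yl on the sulfonyl sulfur gave a 1.3-fold lower number from compound 2 to compound 4 (0.10 log units; within the scatter), so this step too stayed within the usual scatter. Set beside the earlier step, the change reads the same on both cores: the same change on two cores in this assay, a 1.1-fold higher number (0.05 log units; within the scatter) from compound 1 to compound 3 and a 1.3-fold lower number (0.10 log units; within the scatter) from compound 2 to compound 4, 1.4-fold (0.16 log units) apart, within the scatter of two such steps

Going by these compounds alone, this shows that the swap carried over to the second core without a measurable shift on this read-out, but it rests on only two cores and one cell line, and neither step is large enough to show a real effect of the change in either direction. The two pairs therefore do not show that a change that does move the number would carry over in the same way.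

On these data alone, the groups on the sulfonyl sulfur in these compounds are only 5-bromothiophen-2-yl and 4-chlorophenyl, so it remains open whether a plain alkyl chain or a ring bearing an amine would follow the two cores alike. Also open, as far as these compounds go, is how the swap would read on a core bearing a carboxylic acid in place of the ester.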